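Working notes: chain extension from compound 3

The compounds below may be only part of what the source reports. "The series", "measured", "known", "first", "only" and "open" are said of these compounds alone.

compound 1 `CCCCCC[C@@]1(C)SC(O)=CC1=O` gives 16.5 ug/mL
compound 2 `CCCCCCCC[C@@]1(C)SC(O)=C(C)C1=O` gives 16.5 ug/mL
compound 3 `CCCCCC[C@@]1(C)SC(=O)C=C1OC` gives 14 ug/mL

All three compounds were tested in a functional assay on MCF7 cells (Homo sapiens) for inhibition (a lower number here means a stronger inhibitor, a higher number a weaker inhibitor), and compound 3 stands within the scatter of both compound 1 and compound 2 on these numbers.

Compound 4 `CCCCCCCC[C@@]1(C)SC(=O)C=C1OC` carries one change from compound 3, namely ethyl in place of hydrogen on a saturated chain carbon, six bonds along the chain from a saturated ring carbon in the form of ethyl in place of hydrogen on a saturated chain carbon, six bonds along the chain from a saturated ring carbon.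

Among the measured compounds shown here, no measured pair isolates this change. The nearest evidence is indirect. The chain of compound 4 also occurs in compound 2 at 16.5 ug/mL and this value matches that of compound 1, although that pair also differs elsewhere on the core. No step beyond the scatter is therefore expected in this assay in either direction.

The step of no change at the digits printed from compound 3 to compound 4 (within the scatter) is the expected outcome of this change. For compound 4 the estimated value is 14 ug/mL with an expected range from 8 ug/mL to 24 ug/mL in this assay.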

Compound 4, half-maximal inhibitory concentration: > 50 ug/mL
Compound 4: a limit, no number; the forecaster's own chance of this, stated with the estimate: 3%; middle value at least 3.5-fold (0.55 log units) from the limit.
By their numbers in this assay, from the lowest: compounds 3, 1 and 2 (each within the scatter of the next). At a limit, above all of these: compound 4.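

Compound 4 gives > 50 ug/mL in this assay, which is a limit of the assay and not a number. Among the compounds shown here, this is the first pair that isolates a single change, and ethyl in place of hydrogen on a saturated chain carbon, six bonds along the chain from a saturated ring carbon, gives an at least 3.5-fold higher number from compound 3 to compound 4 (0.55 log units; beyond the scatter), so this position on the core of compound 3 does not accept the change without a loss of inhibition. The size of the step is known from one side only: the limit of > 50 ug/mL in this assay, at which 1 of the 4 values shown sits.

Open, from the compounds shown here alone, is whether methyl, a longer chain or an amine at this position would behave as ethyl does. Also open is whether the same step holds on the cores of compound 1 and compound 2, which no pair shown can isolate.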